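Swapping a phenylsulfanyl for a ring-bearing sulfonyl group

The source may report more compounds than this note shows. Statements on the series, on what has been measured and on what is new or still open speak of the compounds shown alone.

Of the compounds shown here, three sharing one core have been measured in an assay on a protein complex (Cavia porcellus) with sulfonylurea receptors; K-ATP channels (Homo sapiens) as the target; on this read-out lower numbers stand for stronger inhibition and higher numbers for weaker inhibition. Compound 1 `CC(O)(C(=O)Nc1ccc(Sc2ccccc2)cc1)C(F)(F)F` carries a phenylsulfanyl group on its aromatic ring. In this assay compound 1 gives only a limit, > 30000 nM, which is the edge of what the assay reports rather than a number, so compound 1 stands at the weak end of the series (the limit of > 30000 nM in this assay, at which 1 of the 3 values shown sits). Compound 3 `CN(C)S(=O)(=O)c1ccc(NC(=O)C(C)(O)C(F)(F)F)cc1` replaces that group with a dimethylsulfamoyl group and gives 480 nM. Compound 2 `CCCN(CCC)S(=O)(=O)c1ccc(NC(=O)C(C)(O)C(F)(F)F)cc1` carries a dipropylamino on the sulfonyl sulfur instead and gives 6440 nM.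

For the measured compounds named here, two steps bear on the new compound. Changing dimethylsulfamoyl for phenylsulfanyl on an aromatic carbon gave an at least 62-fold lower number from compound 1 to compound 3 (1.79 log units; beyond the scatter). Changing dimethylamino for dipropylamino on the sulfonyl sulfur gave a 13-fold lower number from compound 2 to compound 3 (1.13 log units; beyond the scatter), so the smaller amine on the sulfonyl sulfur fares better.

Compound 4 `CC(O)(C(=O)Nc1ccc(S(=O)(=O)N2CCCC2)cc1)C(F)(F)F` differs from compound 1 as follows: (pyrrolidin-1-yl)sulfonyl in place of phenylsulfanyl on an aromatic carbon. The pyrrolidin-1-yl lies between the dimethyl and dipropyl amines in size, so a large gain is expected, an at least 30-fold lower number from compound 1 to compound 4 (1.47 log units; beyond the scatter). For compound 4 the estimate in this assay is 1000 nM, within 250 nM to 4000 nM.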

Compound 4, half-maximal inhibitory concentration: 880 nM
Compound 4: middle estimate off by 1.1-fold (0.06 log units), on the high side; the measured number falls inside the stated range.
By their numbers in this assay, from the lowest: compounds 3 and 4 (each within the scatter of the next); then compound 2. At a limit, above all of these: compound 1.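

In this assay, the gain over phenylsulfanyl does not depend on a single open-chain amine, since a sulfonyl group carrying the ring amine pyrrolidin-1-yl also gives an at least 34-fold lower number from compound 1 to compound 4 (1.53 log units; beyond the scatter). Compound 1 remains a limit, so this step has a floor and no exact size: the limit of > 30000 nM in this assay, at which 1 of the 4 values shown sits. On the sulfonyl sulfur, the pyrrolidin-1-yl ring gives a 1.8-fold higher number from compound 3 to compound 4 (0.26 log units; within the scatter), so it cannot be told apart from dimethylamino, while replacing dipropylamino gives a 7.3-fold lower number from compound 2 to compound 4 (0.86 log units; beyond the scatter).

From the compounds shown here alone, it remains open whether a piperidine or morpholine ring, or an amine with a single methyl, would hold up on the sulfonyl sulfur. Going by these compounds, it is also open whether the amine is needed at all, as a methyl sulfone would show, since the sulfonyl group and an amine always occur together in compounds 2, 3 and 4.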